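The source may report more compounds than this note shows. Statements on the series, on what has been measured and on what is new or still open speak of the compounds shown alone.

Compound 1 `COc1cccc(C(=O)Oc2cc3c(cc2C)[C@@H](C(C)C)CC=C3C)c1` carries a 3-methoxyphenyl group on the shared core. In a functional assay on PC-3 cells (Homo sapiens) for antiproliferative activity, read by sulforhodamine B assay, with a stated time of 48 h, tested at 50 uM (a lower number here means less inhibition, a higher number more inhibition at the concentration tested (going by the name of the read-out)), compound 1 gives 16.3%, the lower of the two numbers recorded. Compound 2 `Cc1cc2c(C(C)C)ccc(C)c2cc1OC(=O)c1cccc(C(F)(F)F)c1` gives 26.7% in this assay, which stands beyond the scatter above compound 1. Compound 3 `CC1=CC[C@H](C(C)C)c2cc(C)c(OC(=O)c3ccccc3)cc21` has not yet been measured and differs from compound 1 by hydrogen in place of methoxy on an aromatic carbon. Among the measured compounds shown here, with no step between measured compounds to guide the size of this change, compound 3 is expected to remain close to compound 1, the step of a number 1.3 percentage points lower from compound 1 to compound 3 (within the scatter) estimated to lie within the scatter. The estimate for compound 3 in this assay is 15%, within 5% to 30%.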

Compound 3, a percentage reported as inhibition, at one concentration (the size of the read-out at that concentration, not a potency): 22.5%
Beside the measured number, compound 3's estimate is 7.5 percentage points below it; low and high end bracket the measured number.
By their numbers in this assay, from the lowest: compounds 1, 3 and 2 (each within the scatter of the next, the first and the last beyond it).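

In this assay, among the compounds shown here, hydrogen in place of methoxy on this aromatic carbon gives a number 6.2 percentage points higher from compound 1 to compound 3 (within the scatter), the first step that can be read at this position. At the tested concentration, the 3-methoxyphenyl to phenyl change therefore leaves the inhibition within the scatter. Nothing at hand accounts for this result. The compounds shown leave open whether an amine, a carboxylic acid or a longer chain on this aromatic carbon would give a step beyond the scatter. They also leave open whether the same change would give a similar step on another core.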